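The source may hold more compounds than are shown below. What is called first, only, known or untested is meant among the compounds shown, and "the series" means these compounds.

Working notes on the series: compound 1 `CC#C[C@H]1CN(S(=O)(=O)c2ccc(N)nc2)CCN1c1ccc(S(=O)(=NC)C(F)(F)F)cc1` and compound 2 `CC#C[C@H]1CN(S(=O)(=O)c2ccc(N)nc2)CCN1c1ccc(S(C)(=N)=O)cc1` are measured, while compound 3 `CC#C[C@H]1CN(S(=O)(=O)c2ccc(N)nc2)CCN1c1ccc([C@](O)(CO)C(F)(F)F)cc1` is still open. In an ADME assay (liver) for metabolic stability, with Liver microsome (Rattus norvegicus) as the target, using microsomes and NADPH, with a stated time of 30 min (a higher number here means faster removal of the compound, a lower number slower removal), compound 1 gives 257 mL.min-1.g-1. Compound 2 gives < 14 mL.min-1.g-1, which is a limit of the assay and not a number. Compound 2 therefore stands at the limit of < 14 mL.min-1.g-1 in this assay, at which 1 of the 2 values shown sits.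

The change to compound 3 is a group of 8 heavy atoms (3 carbon, 2 oxygen, 3 fluorine; no ring) in place of a group of 4 heavy atoms (1 carbon, 1 nitrogen, 1 oxygen, 1 sulfur; no ring), on an aromatic carbon. The entering group is 1,2-dihydroxy-1-(trifluoromethyl)ethyl, on an aromatic carbon of a six-membered aromatic ring of carbon only, para to a large group.

Among the compounds with values here, one measured step bears on this: an at least 18-fold lower number from compound 1 to compound 2 (1.26 log units; beyond the scatter). That large step removed a group of the same heavy-atom count as the one now entering, and that group also held trifluoromethyl. The two groups otherwise differ, so this single step is only a loose guide. A rise in this assay is expected, but much smaller than the size of that step, leaving compound 3 closer to compound 2 than to compound 1.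

The expected step is an at least 2.1-fold higher number from compound 2 to compound 3 (0.33 log units; beyond the scatter). Compound 3 is estimated at 30 mL.min-1.g-1, with an expected range of 14 mL.min-1.g-1 to 90 mL.min-1.g-1.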

Compound 3, intrinsic clearance in microsomes: < 14 mL.min-1.g-1
Compound 3 gave a limit, no number; the forecaster's own chance of this, stated with the estimate: 35%; middle value at least 2.1-fold (0.33 log units) from the limit.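

In this assay, 1,2-dihydroxy-1-(trifluoromethyl)ethyl, on an aromatic carbon of a six-membered aromatic ring of carbon only and para to a large group, gives an at least 18-fold lower number from compound 1 to compound 3 (1.26 log units; beyond the scatter), a large step of the same readable size as an at least 18-fold lower number from compound 1 to compound 2 (1.26 log units; beyond the scatter). Within the data shown here, two groups that share no more than their place on the ring, one with sulfur and one without, therefore both end far from compound 1, and a group holding trifluoromethyl with the same heavy-atom count as the one in compound 1 does not by itself go with the high number of compound 1. The step between compound 2 and compound 3 cannot be read, and no order can be given for these two compounds, because each value is a limit of the assay and not a number: the limit of < 14 mL.min-1.g-1 in this assay, at which 2 of the 3 values shown sit.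

Where compound 2 and compound 3 truly lie under that limit stays open, so the two groups cannot be ranked against each other in this assay. Also open, going by these compounds, is whether a smaller group at the same place, such as a primary amine or a carboxylic acid, would stay at that limit or move back towards compound 1.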